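The compounds below may be only part of what the source reports. "The series", "measured", "known", "first", "only" and "open" are said of these compounds alone.

Measured so far in a functional assay on SK-N-SH cells (Homo sapiens) for inhibition, read by MTT assay; a lower number here means a stronger inhibitor, a higher number a weaker inhibitor:

- compound 1 `CCCCCCCCn1cc(/C=C/C(=O)c2ccc(NC(=O)CBr)cc2)nn1`: compound 1 gives 8460 nM
- compound 2 `Nc1ccc(C(=O)/C=C/c2cn(Cc3ccc(Br)cc3)nn2)cc1`: compound 2 gives 25200 nM

Compound 2 stands highest of the two numbers in this assay; its nearest neighbour is compound 1, whose lower number lies beyond the scatter, so compound 2 is the weaker inhibitor of the pair. Going by the values given here, the two differ in more than one place, so no single step links them.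

The next compound, compound 3 `O=C(CBr)Nc1ccc(C(=O)/C=C/c2cn(Cc3ccc(Br)cc3)nn2)cc1`, differs from compound 2 in one place: (bromomethyl)carbonyl in place of hydrogen on a nitrogen on an aromatic ring. Put in words, the amino group of compound 2 becomes a ((bromomethyl)carbonyl)amino group, the same group carried by compound 1 on its own core.

Compound 1, which already holds this group, sits at the lower number of the two measured, while compound 2 without it sits at the higher. On that basis the step from compound 2 to compound 3 is expected to lower the number, estimated at a 3.2-fold lower number from compound 2 to compound 3 (0.50 log units; beyond the scatter), a shift beyond the scatter. Compound 3 is accordingly expected to reach about 8000 nM in this assay, within a range of 3000 nM to 20000 nM.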

Compound 3, half-maximal inhibitory concentration: 8300 nM
Compound 3: the middle estimate sits 1.0-fold (0.02 log units) below what was measured, within the range that was stated.
By their numbers in this assay, from the lowest: compounds 3 and 1 (each within the scatter of the next); then compound 2.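

In this assay, the step at this nitrogen on an aromatic ring can now be read in one place: a 3.0-fold lower number from compound 2 to compound 3 (0.48 log units; beyond the scatter), so amino to ((bromomethyl)carbonyl)amino is a modest change beyond the scatter on this core. With that group present in both compounds, 4-bromophenyl in place of heptyl on a saturated chain carbon bound to an aromatic nitrogen gives a 1.0-fold lower number from compound 1 to compound 3 (0.01 log units; within the scatter), which lies within the scatter, so this pair shows no separation between the two groups at that place. Nothing at hand accounts for either step.

Still open, as far as these compounds go, is how an acetyl group or a (chloromethyl)carbonyl group on the same nitrogen would read against compound 3, which leaves the contribution of the bromine in the (bromomethyl)carbonyl group unsettled. Also open is whether amino to ((bromomethyl)carbonyl)amino gives a comparable step when heptyl replaces 4-bromophenyl, as the amino counterpart of compound 1 is not among the compounds shown.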